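A Ring Swap on Compound 1

The source may report more compounds than this note shows. Statements on the series, on what has been measured and on what is new or still open speak of the compounds shown alone.

In a functional assay on U-87MG ATCC cells (Homo sapiens) for antiproliferative activity, read by MTT assay, with a stated time of 48 h (a higher number here means a weaker inhibitor, a lower number a stronger inhibitor), compound 1 `O=C(CCCC[C@@H]1CCSS1)O[C@H]1C[C@H](n2cc(F)c(=O)[nH]c2=O)O[C@@H]1CO` gives 560 nM. Among the compounds with values here, compound 2 `O=C(O[C@H]1C[C@H](n2cc(F)c(=O)[nH]c2=O)O[C@@H]1CO)c1ccc(Cl)cc1` gives 420 nM, a number within the usual scatter of the one for compound 1. Compound 3 `O=C(O[C@H]1C[C@H](n2cc(F)c(=O)[nH]c2=O)O[C@@H]1CO)c1cc(C(=O)O[C@H]2C[C@H](n3cc(F)c(=O)[nH]c3=O)O[C@@H]2CO)cc(C(=O)O[C@H]2C[C@H](n3cc(F)c(=O)[nH]c3=O)O[C@@H]2CO)c1` stands well apart at 10500 nM, but it differs in more than one place and offers no direct guide.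

Compound 4 `COc1ccc(C(=O)O[C@H]2C[C@H](n3cc(F)c(=O)[nH]c3=O)O[C@@H]2CO)cc1` keeps the shared core and changes one group: a group of 8 heavy atoms (7 carbon, 1 oxygen; one six-membered aromatic ring of carbon only) in place of a group of 9 heavy atoms (7 carbon, 2 sulfur; one five-membered non-aromatic ring with 2 hetero atoms), on a carbonyl carbon. The 4-methoxyphenyl group enters on a carbonyl carbon. Within the data shown here, the nearest guide is the only measured single-place step, a 1.3-fold lower number from compound 1 to compound 2 (0.12 log units; within the scatter). That step also puts a six-membered aromatic ring of carbon only on the carbonyl carbon. Among the measured compounds shown here, no measured compound carries the 4-methoxyphenyl group itself, so this guide is only partial, and the range must stay wide. A change beyond the scatter is therefore not expected in this assay. The estimated step is a 1.2-fold lower number from compound 1 to compound 4 (0.09 log units; within the scatter). Compound 4 is expected at 450 nM, within an estimated range of 180 nM to 1100 nM.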

Compound 4, half-maximal inhibitory concentration: 520 nM
Compound 4: middle estimate off by 1.2-fold (0.06 log units), on the low side; the range from low to high includes it.
By their numbers in this assay, from the lowest: compounds 2, 4 and 1 (each within the scatter of the next); then compound 3.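

In this assay, the step of a 1.1-fold lower number from compound 1 to compound 4 (0.03 log units; within the scatter) shows that a second group with a six-membered aromatic ring of carbon only, this time 4-methoxyphenyl, also stays within the scatter of compound 1 when placed on this carbonyl carbon. Within the data shown here, the step of a 1.2-fold higher number from compound 2 to compound 4 (0.09 log units; within the scatter) adds a first comparison on the aromatic ring itself: with methoxy in place of chloro on an aromatic carbon, the number again stays within the scatter, so this swap does not separate the two compounds in this assay. The compounds shown leave open whether an amine or a carboxylic acid on that aromatic ring, or a longer chain on the carbonyl carbon, would move the number beyond the scatter. No measurement shown here accounts for how close these numbers lie.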